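Fluoro in place of hydrogen on compound 2

A few compounds are considered here, and "the series" means these few. Any claim that something is new, unique, unknown or untested is made for them only; others in the source may bear on it.

Measured in a functional assay on HeLa cells (Homo sapiens) for inhibition, read by MTT assay, with a stated time of 72 h; on this read-out higher numbers stand for weaker inhibition and lower numbers for stronger inhibition:
- compound 1 `COc1cccc(/C=C/C(=O)Nc2cc(OC)c(OC)c(OC)c2)c1`: 16500 nM
- compound 2 `C=C(Br)C(=O)Nc1cccc(/C=C/C(=O)Nc2ccccc2)c1`: 7300 nM

Compound 2 has the lower of the two numbers, and its gap to compound 1 lies beyond the scatter. Compound 3 `C=C(Br)C(=O)Nc1cccc(/C=C/C(=O)Nc2cccc(F)c2)c1` follows from compound 2 by fluoro in place of hydrogen on an aromatic carbon, phenyl to 3-fluorophenyl (fluoro in place of hydrogen on an aromatic carbon). Going by the values given here, no measured pair shows this change, so the expectation in this assay is a small shift to a lower number, not beyond the scatter. The expected step is a 1.2-fold lower number from compound 2 to compound 3 (0.09 log units; within the scatter). For compound 3 the estimate is 6000 nM, with an expected range of 2500 nM to 14000 nM.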

Compound 3, half-maximal inhibitory concentration: 1200 nM
Beside the measured number, compound 3's estimate is 5.0-fold (0.70 log units) above it; the whole stated range lies above it.
By their numbers in this assay, from the lowest: compound 3; then compound 2; then compound 1.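

In this assay, going by these compounds alone, phenyl to 3-fluorophenyl gives a 6.1-fold lower number from compound 2 to compound 3 (0.78 log units; beyond the scatter) and is the first single-place change. It shows that this aromatic carbon is sensitive to substitution: one fluorine atom in place of hydrogen, with the rest of compound 2 unchanged, moves the number beyond the scatter. Nothing at hand explains the size of this step.

Going by these compounds, whether chloro, methoxy or an amine on this carbon would act as fluoro does remains open. So does whether fluoro on another carbon of this ring gives a similar step.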